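Halogen swap at the aryl ring of compound 3

The source may report more compounds than this note shows. Statements on the series, on what has been measured and on what is new or still open speak of the compounds shown alone.

Three members of the series have numbers in a functional assay on cardiac atrium for agonist activity at histamine H2 receptor (Cavia porcellus); a lower number here means a less potent compound, a higher number a more potent compound, by a factor of ten per unit of this negative logarithm. Compound 1 `N=C(NCCCc1c[nH]cn1)NCCCC(c1ccc(F)cc1)c1ccccn1` gives 6.87 in this assay, compound 2 `COc1ccc(C(CC/N=C(\N)NCCCc2c[nH]cn2)c2ccccn2)cc1` gives 7.44, and compound 3 `N=C(NCCCc1c[nH]cn1)NCCC(c1ccc(F)cc1)c1ccccn1` gives 8.01. Compound 3 stands highest of the three, beyond the scatter above compound 2 and further still above compound 1. Compound 4 `N=C(NCCCc1c[nH]cn1)NCCC(c1ccc(Br)cc1)c1ccccn1` differs from compound 3 in one place: bromo in place of fluoro on an aromatic carbon of a six-membered aromatic ring of carbon only, para to a large group. Going by the values given here, no measured pair shows this change, so its size is unknown. The expected step in this assay is a number 0.01 log units lower from compound 3 to compound 4 (within the scatter), none beyond the scatter. Compound 4 is estimated at 8 in this assay, within a range of 7.4 to 8.6.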

Compound 4, negative logarithm of the half-maximal effective concentration: 7.48
For compound 4 the middle estimate is 0.52 log units above the measured one; low and high end bracket the measured number.
By their numbers in this assay, from the lowest: compound 1; then compounds 2 and 4 (each within the scatter of the next); then compound 3.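

In this assay, going by these compounds alone, the halogen at this place matters, with a number 0.53 log units lower from compound 3 to compound 4 (beyond the scatter) as the first one-place step. The 4-fluorophenyl to 4-bromophenyl change, on an aromatic carbon para to a large group, thus favours fluoro in this pair. No available data explain the difference.

Going by these compounds, with only fluoro and bromo compared in one-place steps, it remains open where a chloro or a methyl group at this place would fall. Also open, on these data alone, is whether the same swap gives a similar step on the longer chain of compound 1.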